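The compounds below may be only part of what the source reports. "The series", "measured", "known", "first", "only" and "open" are said of these compounds alone.

For the measured compounds named here, compound 2 `CC#CC(CC(=O)O)c1ccc(OCc2ccc(C(=O)N3CCN(c4ccc(C(C)(C)C)cc4)CC3)s2)cc1` stands at the higher of the two numbers measured so far: in a functional assay on HEK293 cells for agonist activity at Free fatty acid receptor 1 (Homo sapiens), read by fluorescence and calcium flux (on this read-out higher numbers stand for an effect only at larger amounts of compound and lower numbers for an effect already at smaller amounts), compound 2 gives 417 nM. Going by the values given here, its only neighbour, compound 1 `CC#CC(CC(=O)O)c1ccc(OCc2ccc(C(=O)N3CCN(c4ccc(C)cc4)CC3)s2)cc1`, gives 211 nM in this assay, and the step of a 2.0-fold higher number from compound 1 to compound 2 (0.30 log units; within the scatter) stays within the scatter of repeated measurements. Compound 3 `CC#CC(CC(=O)O)c1ccc(OCc2ccc(C(=O)N3CCN(c4ccc([N+](=O)[O-])cc4)CC3)s2)cc1` differs from compound 2 in one place: nitro in place of tert-butyl on an aromatic carbon. Among the compounds with values here, the single measured step exchanged methyl for tert-butyl at this position; the exchange of tert-butyl for nitro is a different kind of change, and no measured step bears directly on it. Without a precedent, no direction beyond the scatter can be claimed, so the step from compound 2 to compound 3 is expected to be about a 1.0-fold lower number from compound 2 to compound 3 (0.02 log units; within the scatter), with a wide range. Compound 3 is therefore estimated at 400 nM, most likely between 120 nM and 1500 nM.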

Compound 3, half-maximal effective concentration: 231 nM
The estimate for compound 3 lay 1.7-fold (0.24 log units) above the measured number; measured number inside the range.
By their numbers in this assay, from the lowest: compounds 1, 3 and 2 (each within the scatter of the next).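

At this position on the six-membered aromatic ring, in this assay, putting nitro in place of tert-butyl gives a 1.8-fold lower number from compound 2 to compound 3 (0.26 log units; within the scatter), and putting it in place of methyl gives a 1.1-fold higher number from compound 1 to compound 3 (0.04 log units; within the scatter). Nitro brings nitrogen, oxygen and two hydrogen-bond acceptors to a place that held only carbon in the earlier compounds, yet all three compounds remain within the scatter of one another, so a change of atoms this large has no readable effect on the number here. Nothing available explains this result.

From the compounds shown here alone, what an amine, a carboxylic acid or a longer chain would give at this position remains open. Whether nitro would give a similar number elsewhere on the ring is also an open question.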